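This account rests on a few compounds, and the source may have more. Where it says the series, first, only, none or still open, it means among the compounds named here.

Compound 1 `CC(=O)N1N=C(c2cc(O)c(O)c([N+](=O)[O-])c2)CC1c1nccs1` gives 68200 nM in an assay on isolated protein for inhibition of Amine oxidase [flavin-containing] B (Homo sapiens), read by fluorescence; a lower number here means a stronger inhibitor, a higher number a weaker inhibitor.
Compound 2 `CC(=O)N1N=C(c2cc(O)c(O)c([N+](=O)[O-])c2)CC1c1cccc(C#N)c1` gives 55400 nM in this assay.
Compound 3 `O=C(/C=C/c1ccco1)c1cc(O)c(O)c([N+](=O)[O-])c1` gives 68200 nM in this assay.

Among these three numbers compound 3 stands level with compound 1 at the digits shown, the two of them together the highest of the set; compound 2 lies closest below it, and the gap between compound 3 and compound 2 is within the scatter, so no order can be read among the three. Compound 4 `Cn1cc(/C=C/C(=O)c2cc(O)c(O)c([N+](=O)[O-])c2)cn1` has not yet been measured in this assay. It differs from compound 3 in one place: 1-methyl-1H-pyrazol-4-yl in place of furan-2-yl on a double-bonded chain carbon bound to a double-bonded chain carbon.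

Within the data shown here, only one measured step exists, a 1.2-fold lower number from compound 1 to compound 2 (0.09 log units; within the scatter); it concerns a different group at a different place and was itself within the scatter, so nothing measured speaks for or against the change in compound 4. Compound 4 is therefore expected to sit close to compound 3, with a 1.0-fold lower number from compound 3 to compound 4 (0.00 log units; within the scatter) as the estimated step. The estimated value for compound 4 in this assay is 68000 nM, with a range from 25000 nM to 180000 nM.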

Compound 4, half-maximal inhibitory concentration: 66200 nM
Beside the measured number, compound 4's estimate is 1.0-fold (0.01 log units) above it; the measured number falls inside the stated range.
By their numbers in this assay, from the lowest: compounds 2, 4, 1 and 3 (each within the scatter of the next).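

Replacing furan-2-yl with 1-methyl-1H-pyrazol-4-yl on the double-bonded chain carbon gives a 1.0-fold lower number from compound 3 to compound 4 (0.01 log units; within the scatter) in this assay. Among these compounds, this is the first measured step at this place, and it shows that moving from a five-membered aromatic ring with 1 hetero atom and 1 hydrogen-bond acceptor to one with 2 of each leaves the number within the scatter for this pair. Nothing measured here offers an explanation for this outcome.

Whether any group at this place can move the number beyond the scatter remains open, since only these two five-membered aromatic rings are shown there. As far as these compounds go, a group of a different kind, such as an aliphatic amine or a carboxylic acid, could test this, and the effect of changes to the shared core also remains unknown.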